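Working notes on a shared-core series: cytotoxicity

The source may report more compounds than this note shows. Statements on the series, on what has been measured and on what is new or still open speak of the compounds shown alone.

Three compounds have been measured in a functional assay on HT-1080 cells (Homo sapiens) for cytotoxicity, read by MTT assay, with a stated time of 72 h; a higher number here means a weaker inhibitor, a lower number a stronger inhibitor:

compound 1 `COc1cccc(/C=C2\CCC/C(=C\c3ccc(Cl)cc3)C2=O)c1OC` — 11100 nM
compound 2 `COc1cccc(/C=C2\CCC/C(=C\c3ccccc3Br)C2=O)c1OC` — 10800 nM
compound 3 `COc1ccccc1/C=C1\CCC/C(=C\c2cccc(OC)c2OC)C1=O` — 14100 nM

Compound 1 stands second highest of the three numbers. Its nearest neighbour is compound 2, with a 1.0-fold lower number from compound 1 to compound 2 (0.01 log units; within the scatter); its furthest is compound 3, with a 1.3-fold higher number from compound 1 to compound 3 (0.10 log units; within the scatter). Between the other two, a 1.3-fold higher number from compound 2 to compound 3 (0.12 log units; within the scatter). All three numbers therefore sit within the usual scatter of one another, and no ordering among them can be claimed.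

Compound 4 `COc1cccc(/C=C2\CCC/C(=C\c3ccc(O)c(Cl)c3)C2=O)c1OC` is not yet measured. Relative to compound 1 the change is:
3-chloro-4-hydroxyphenyl in place of 4-chlorophenyl on a double-bonded chain carbon bound to a double-bonded ring carbon

Among the compounds with values here, the steps that bear on this are the two aryl exchanges from compound 1, to compound 2 and to compound 3, both within the scatter. Within the data shown here, neither introduces a hydroxy group, so the series gives no direct precedent for the hydrogen-bond donor that enters. On the numbers shown, no step beyond the scatter is expected in this assay. Compound 4 is expected to give 11000 nM, with a range of 5000 nM to 25000 nM. The expected step is a 1.0-fold lower number from compound 1 to compound 4 (0.00 log units; within the scatter).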

Compound 4, half-maximal inhibitory concentration: 14300 nM
Compound 4: the middle estimate sits 1.3-fold (0.11 log units) below what was measured; the range from low to high includes it.
By their numbers in this assay, from the lowest: compounds 2, 1, 3 and 4 (each within the scatter of the next).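

In this assay, within the data shown here, the step of a 1.3-fold higher number from compound 1 to compound 4 (0.11 log units; within the scatter) shows that this place, on a double-bonded chain carbon bound to a double-bonded ring carbon, accepts 3-chloro-4-hydroxyphenyl, the first group here with a hydrogen-bond donor, without a step beyond the scatter. The comparisons with the other aryl groups read the same, with a 1.0-fold higher number from compound 3 to compound 4 (0.01 log units; within the scatter) and a 1.3-fold higher number from compound 2 to compound 4 (0.12 log units; within the scatter) both printed as within the scatter, so the hydroxy group brings no readable separation from any earlier compound. No measured evidence bears on why this is so.

The compounds shown leave open whether a 4-hydroxyphenyl without chloro would read the same as compound 4. They also leave open whether an amine or a carboxylic acid at this place would give a step beyond the scatter.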